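From oxetan-3-yl to oxolan-3-yl on an amide nitrogen

A few compounds are considered here, and "the series" means these few. Any claim that something is new, unique, unknown or untested is made for them only; others in the source may bear on it.

Compound 1 `O=C([C@@H]1CCCN(S(=O)(=O)c2ccc(S(=O)(=O)C3CCC3)cc2)C1)N1CCC(F)(F)CC1` gives 78 nM
Compound 2 `CCN(CC)S(=O)(=O)c1ccc(S(=O)(=O)N2CCC[C@@H](C(=O)NC3COC3)C2)cc1` gives 13800 nM

Both compounds were tested in a functional assay on BXPC-3 cells (Homo sapiens) for inhibition, read by MTT assay, with a stated time of 7 days (on this read-out lower numbers stand for stronger inhibition and higher numbers for weaker inhibition), and gave the numbers above. Compound 2 holds the higher of the two numbers, which makes it the weaker inhibitor of the pair, and the gap to compound 1 lies well beyond the scatter.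

Compound 3 `CCN(CC)S(=O)(=O)c1ccc(S(=O)(=O)N2CCC[C@@H](C(=O)N[C@@H]3CCOC3)C2)cc1` has not been measured yet. It keeps everything in compound 2 except one group: oxolan-3-yl in place of oxetan-3-yl on an amide-type nitrogen. Among the compounds with values here, no measured pair shows what such a swap does, and compound 1 differs from compound 2 in more than one place, so it offers little guidance. That leaves compound 2 at 13800 nM as the starting point for the expectation. Within the data shown here, only this one group changes, so in this assay no step beyond the scatter is expected, with a slight lean toward a lower number. The expected step (a 1.5-fold lower number from compound 2 to compound 3 (0.19 log units; within the scatter)) therefore stays small. Compound 3 is expected at 9000 nM (expected range 3000 nM to 25000 nM).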

Compound 3, half-maximal inhibitory concentration: 2270 nM
For compound 3 the middle estimate is 4.0-fold (0.60 log units) above the measured one, outside the stated range (below it).
By their numbers in this assay, from the lowest: compound 1; then compound 3; then compound 2.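

In this assay, enlarging the ring on the amide-type nitrogen from oxetan-3-yl to oxolan-3-yl gives a 6.1-fold lower number from compound 2 to compound 3 (0.78 log units; beyond the scatter), a step large enough to stand clear of repeat-to-repeat variation. This shows that the position is sensitive to even a small change in the ring: the ring oxygen stays, the counted hydrogen-bond donors and acceptors of the group stay the same, neither group carries a net charge, and the number still moves. The change from a four-membered to a five-membered ring also brings in a defined stereocentre, and no measurement shown here explains why this swap lowers the number.

As far as these compounds go, the oxolan-3-yl group appears in only one of its two mirror-image forms, so the effect of the opposite arrangement at that stereocentre remains open, as does how much of the step comes from ring size alone. Also open, from the compounds shown here alone, is how this amide nitrogen would respond to a six-membered oxan-4-yl ring, an all-carbon cyclopentyl ring or an open 2-methoxyethyl chain, any of which would show whether the trend continues and whether the ring oxygen matters.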